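Benzyl ether to butyl carbamate on the shared core

The compounds below may be only part of what the source reports. "The series", "measured", "known", "first", "only" and "open" are said of these compounds alone.

Of the compounds shown here, three have been read in an assay on nucleic acid for inhibition of Nucleic Acid, read by fluorescence, tested at 100 uM; a higher number here means more inhibition at the concentration tested (going by the name of the read-out), a lower number less inhibition. Compound 1 `CN(Cc1cn(C2CCCCC2OC(=O)c2ccccc2)nn1)CC1CCCCC1` gives 32%. Compound 2 `CCCCCCCC(=O)OCC(O)Cn1cc(CN2CCN(c3ccccc3)CC2)nn1` gives 26%. Compound 3 `OC(COCc1ccccc1)Cn1cc(CN2CCN(c3ccccc3)CC2)nn1` gives 37%, the top number of the three on paper, though its gap to compound 1 lies within the scatter and only its gap to compound 2 lies beyond it. For the measured compounds named here, the one measured step between close relatives is a number 11 percentage points higher from compound 2 to compound 3 (beyond the scatter), so removing a carbonyl-bearing chain from that oxygen in favour of benzyl raised inhibition by a modest margin.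

Compound 4 `CCCCNC(=O)OCC(O)Cn1cc(CN2CCN(c3ccccc3)CC2)nn1` returns a carbonyl to the same oxygen: butylcarbamoyl in place of benzyl on an oxygen on a saturated carbon. The step from compound 2 to compound 3 is the only one that bears on this change, and it ran in the opposite direction, with the heptylcarbonyl partner sitting at the low end of the set. The group entering here carries a carbonyl too, but with an amide hydrogen and a shorter chain, so a reversal of the gain seen in compound 3 is expected, in the direction of compound 2, with the step of a number 9 percentage points lower from compound 3 to compound 4 (within the scatter) estimated to lie near the edge of the scatter. Compound 4 is therefore estimated at 28%, within a range from 16% to 40%.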

Compound 4, a percentage reported as inhibition, at one concentration (the size of the read-out at that concentration, not a potency): 11%
For compound 4 the middle estimate is 17 percentage points above the measured one; measured number below the stated range.
By their numbers in this assay, from the lowest: compound 4; then compounds 2, 1 and 3 (each within the scatter of the next, the first and the last beyond it).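

In this assay, for the compounds shown here, the position on an oxygen on a saturated carbon proves more sensitive than the earlier compounds showed: with benzyl replaced by butylcarbamoyl, the number falls (a number 26 percentage points lower from compound 3 to compound 4 (beyond the scatter)), and among compounds 2, 3 and 4, which share the core, both carbonyl-bearing groups now read lower than benzyl, with none of the three going against this. The carbonyl alone does not settle the reading, since the two carbonyl-bearing groups also differ from each other, with butylamino in place of heptyl on a carbonyl carbon lowering the number further (a number 15 percentage points lower from compound 2 to compound 4 (beyond the scatter)). Nothing measured here gives a reason for either step.

As far as these compounds go, what remains open is whether the lower reading of compound 4 goes with the nitrogen on the carbonyl carbon or with the shorter chain, as that step changes both at once, and a heptylamino or a butyl group on the same carbonyl carbon would separate the two. From the compounds shown here alone, it is also open whether the aromatic ring of benzyl matters or any carbonyl-free group would serve, which a cyclohexylmethyl or a plain butyl group on that oxygen would test.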